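A few compounds are considered here, and "the series" means these few. Any claim that something is new, unique, unknown or untested is made for them only; others in the source may bear on it.

Measured so far in a functional assay on HeLa cells (Homo sapiens) for inhibition, read by CCK-8 assay, with a stated time of 48 h; on this read-out higher numbers stand for weaker inhibition and lower numbers for stronger inhibition:
compound 1 `O=C(NCCNS(=O)(=O)c1ccc(-c2ccccc2O[C@H]2CC[C@H](O)CC2)s1)Nc1cc(C(F)(F)F)cc(C(F)(F)F)c1`: > 20000 nM
compound 2 `O=C(NCCNS(=O)(=O)c1ccc(-c2ccccc2OCc2cccc(O)c2)s1)Nc1cc(Cl)cc(Cl)c1`: > 50000 nM
compound 3 `COc1ccc(Oc2ccc([N+](=O)[O-])cc2-c2ccsc2S(=O)(=O)N2CCN(C(=S)Nc3ccc([N+](=O)[O-])cc3)CC2)cc1OC`: > 50000 nM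

All three numbers are limits of this assay rather than true values. For compound 1, the value > 20000 nM is a limit. For compound 2, the value > 50000 nM is likewise a limit. For compound 3, the value > 50000 nM is a limit as well. These limits are the limit of > 20000 nM in this assay, at which 1 of the 3 values shown sits, and (the limit of > 50000 nM in this assay, at which 2 of the 3 values shown sit). Compound 2 therefore stands at the upper edge of what this assay reports, and no order among the three compounds can be read from these numbers.

Compound 4 `O=C(NCCNS(=O)(=O)c1ccc(-c2ccccc2OCc2ccccc2)s1)Nc1cc(Cl)cc(Cl)c1` differs from compound 2 in one place: hydrogen in place of hydroxy on an aromatic carbon. No step between two measured compounds is shown here, so nothing measured tells how such a change behaves in this assay. Because compound 2 gives only > 50000 nM, compound 4 is expected to stay at or near that limit, a step of a number no higher from compound 2 to compound 4 (the limit leaves the size open). Compound 4 is estimated at 50000 nM, within 15000 nM to 200000 nM.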

Compound 4, half-maximal inhibitory concentration: > 20000 nM
Compound 4 gave a limit, no number; the forecaster's own chance of this, stated with the estimate: 80%; the middle value lies beyond the limit too.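

Compound 2 and compound 4 each gave only a limit, not a number, so the step between them cannot be read. The compounds shown leave open whether hydrogen in place of hydroxy changes inhibition at all, and what concentration any of them would need to inhibit.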